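Dropping the trifluoromethyl group from an ester on a bicyclic core

A few compounds are considered here, and "the series" means these few. Any claim that something is new, unique, unknown or untested is made for them only; others in the source may bear on it.

Of the compounds shown here, three have been tested so far in a functional assay on U-251 cells (Homo sapiens) for antiproliferative activity, read by sulforhodamine B assay, with a stated time of 48 h, tested at 50 uM; a higher number here means more inhibition at the concentration tested (going by the name of the read-out), a lower number less inhibition. Compound 1 `Cc1cc2c(C(C)C)ccc(C)c2cc1OC(=O)c1cccc(C(F)(F)F)c1` carries a trifluoromethyl group on the ester's aromatic ring and is reported in this assay as "not active" (no number reported), with no number given. Compound 2 `COc1ccc(C(=O)Oc2cc3c(C)ccc(C(C)C)c3cc2C)cc1`, which has a methoxy group in its place and a fully aromatic core, gives 42.6% in this assay. Compound 3 `CC1=CC[C@H](C(C)C)c2cc(C)c(OC(=O)c3cccc(C(F)(F)F)c3)cc21` keeps the trifluoromethyl ester but sits on a partly saturated core; in this assay compound 3 gives 29.3%, the lower of the two numbers reported, and the gap to compound 2 lies beyond the usual scatter.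

Compound 4 `CC1=CC[C@H](C(C)C)c2cc(C)c(OC(=O)c3ccccc3)cc21` is the next compound to be measured in this assay. It differs from compound 3 in a single place: hydrogen in place of trifluoromethyl on an aromatic carbon. For the measured compounds named here, no pair of already measured compounds shows this same change, so there is no measured step to lean on. Given that compound 3 is the weaker of the two numbered results at 29.3%, the expectation is a small downward drift rather than a jump.

For compound 4 the expected step from its parent is a number 5.3 percentage points lower from compound 3 to compound 4 (within the scatter). Compound 4 is therefore estimated at 24%, within a range from 5% to 42%.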

Compound 4, a percentage reported as inhibition, at one concentration (the size of the read-out at that concentration, not a potency): 25.8%
For compound 4 the middle estimate is 1.8 percentage points below the measured one, within the range that was stated.
By their numbers in this assay, from the lowest: compounds 4 and 3 (each within the scatter of the next); then compound 2.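

Hydrogen in place of trifluoromethyl, on an aromatic carbon of the ester's ring, gives a number 3.5 percentage points lower from compound 3 to compound 4 (within the scatter) in this assay. For the compounds shown here, this is the first step that changes one place only, and at the single concentration tested it does not separate the two compounds, so on this partly saturated core the inhibition seen does not depend on the trifluoromethyl group. No measurement is available that could explain this result.

One open question is whether other groups at this place, such as an amine, a carboxylic acid or a longer alkyl chain, would give a number that stands clear of the scatter, since only trifluoromethyl and hydrogen can be compared here on this core. From the compounds shown here alone, it is also open whether hydrogen in place of trifluoromethyl would have the same small effect on the fully aromatic core of compound 1, reported as "not active" (no number reported), and a reading at one concentration says nothing about potency in either case.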